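The source may report more compounds than this note shows. Statements on the series, on what has been measured and on what is new or still open speak of the compounds shown alone.

Measured compounds in an ADME assay on liver (Mesocricetus auratus) for metabolic stability, using microsomes; on this read-out lower numbers stand for slow clearance and higher numbers for fast clearance:
Compound 1 `COc1ccc(C(=O)Nc2[nH]nc(-c3ccccn3)c2C2CC2)cc1`: > 100 mL.min-1.g-1
Compound 2 `O=C(Nc1cc(-c2ccccn2)n[nH]1)N1CCC(c2ccc(F)cc2)CC1`: 272 mL.min-1.g-1

For the measured compounds named here, only two compounds have been tested so far in this assay, and only one of them has given an actual number. Compound 1 is reported as a limit of the assay, > 100 mL.min-1.g-1. Going by the values given here, compound 2, at 272 mL.min-1.g-1, therefore holds the only exact value, and it is a value on the fast-clearance side of the read-out.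

The next compound to be tested is compound 3 `O=C(Nc1cc(-c2ccccn2)n[nH]1)N1CCC(Oc2ccccn2)CC1`. It keeps the structure of compound 2 except for one change, with (pyridin-2-yl)oxy in place of 4-fluorophenyl on a saturated ring carbon. Among the compounds with values here, no measured step covers such a change, so the expectation rests only on the value of compound 2 272 mL.min-1.g-1 and on the swap itself. A modest move towards slower clearance is expected, close to the edge of the usual scatter, and the estimated step is a 2.1-fold lower number from compound 2 to compound 3 (0.32 log units; beyond the scatter). For compound 3 the expected value is 130 mL.min-1.g-1, with an estimated range from 50 mL.min-1.g-1 to 300 mL.min-1.g-1.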

Compound 3, intrinsic clearance in microsomes: 67.3 mL.min-1.g-1
For compound 3 the middle estimate is 1.9-fold (0.29 log units) above the measured one, within the range that was stated.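

In this assay, for the compounds shown here, placing (pyridin-2-yl)oxy in place of 4-fluorophenyl on the saturated ring carbon gives a 4.0-fold lower number from compound 2 to compound 3 (0.61 log units; beyond the scatter), the first step between compounds differing in one place that can be read. It shows that the group on this carbon, three ring bonds from the ring nitrogen, can move the read-out beyond the usual scatter while the rest of compound 2 stays unchanged. The swap keeps the heavy-atom count and the absence of net charge, but it brings in a ring nitrogen, an oxygen and hydrogen-bond acceptors that 4-fluorophenyl lacks, and this single pair cannot tell which of these differences goes with the step.

Still open, as far as these compounds go, is whether the oxygen or the ring nitrogen of the new group goes with the step, and how a simple phenoxy group, a morpholine or a carboxylic acid on the same carbon would compare. Compound 1 remains a limit of the assay rather than a number, so it cannot be placed exactly on this scale: the limit of > 100 mL.min-1.g-1 in this assay, at which 1 of the 3 values shown sits.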